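The compounds below may be only part of what the source reports. "The series", "measured", "known", "first", "only" and "open" are said of these compounds alone.

Measured compounds:
compound 1, `O=c1nc(O)c(C#Cc2ccccc2)cn1[C@@H]1O[C@H](CO)[C@@H](O)[C@H](O)[C@H]1O`, 6200 nM
compound 2, `Nc1nc(=O)n([C@@H]2O[C@H](CO)[C@@H](O)[C@H](O)[C@H]2O)cc1C#Cc1ccccc1`, >= 250000 nM
compound 3, `CC(C)(C)c1ccc(C#Cc2cn([C@@H]3O[C@H](CO)[C@@H](O)[C@H](O)[C@H]3O)c(=O)nc2O)cc1`, 185000 nM

In a functional assay on L1210 cells (Mus musculus) for cytotoxicity, with a stated time of 48 h (on this read-out higher numbers stand for weaker inhibition and lower numbers for stronger inhibition), compound 1 gives 6200 nM. For compound 2 the assay reports only a limit, >= 250000 nM, not a number. Compound 3 gives 185000 nM in this assay, the highest of the two numbers. The change amino in place of hydroxy on an aromatic carbon produces the step of an at least 40-fold higher number from compound 1 to compound 2 (1.60 log units; beyond the scatter). The cores of compound 1 and compound 3 differ by tert-butyl in place of hydrogen on an aromatic carbon, which gives the step of a 30-fold higher number from compound 1 to compound 3 (1.47 log units; beyond the scatter). Compound 4, `CC(C)(C)c1ccc(C#Cc2cn([C@@H]3O[C@H](CO)[C@@H](O)[C@H](O)[C@H]3O)c(=O)nc2N)cc1`, is not yet measured and carries the same kind of change, (amino in place of hydroxy on an aromatic carbon). The two places are not identical: for compound 4 the place reads ortho to a large group, where for compound 2 it reads ortho to a 2-phenylethynyl group (8 heavy atoms). For compound 4 in this assay the step is expected to be a 1.6-fold higher number from compound 3 to compound 4 (0.21 log units; within the scatter). This estimate sits beside an at least 40-fold higher number from compound 1 to compound 2 (1.60 log units; beyond the scatter) and rests on (the limit of >= 250000 nM in this assay, at which 1 of the 3 values shown sits), near which compound 3 already stands. Compound 4 is therefore expected to give 300000 nM, most probably reported only as a limit, in a range from 150000 nM to 1500000 nM.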

Compound 4, half-maximal inhibitory concentration: > 250000 nM
Compound 4: only a limit was reported (the forecaster's own chance of this, stated with the estimate: 85%); the middle value is on the limit's open side.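

On the core carrying tert-butyl, amino in place of hydroxy gives in this assay an at least 1.3-fold higher number from compound 3 to compound 4 (0.13 log units; that floor lies within the scatter), and since compound 4 is reported only as a limit, this step is a floor and not a size. Set beside the same change on the core without tert-butyl, both steps run towards higher numbers, but their sizes cannot be compared: the same change on two cores in this assay, an at least 40-fold higher number (1.60 log units; beyond the scatter) from compound 1 to compound 2 and an at least 1.3-fold higher number (0.13 log units; that floor lies within the scatter) from compound 3 to compound 4; the limit leaves it open whether they differ The data therefore show no reversal of the change on the second core, yet they do not show that its size carries over, and the step between the two amino compounds, compound 2 and compound 4, cannot be read.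

Open, as far as these compounds go, is whether a methoxy or a dimethylamino group in place of hydroxy would leave the number near that of compound 1, 6200 nM. Also open, from the compounds shown here alone, is whether methyl or fluorine in place of tert-butyl would give a smaller step than tert-butyl does, and whether amino on such a compound would stay measurable rather than end at a limit.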